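The compounds below may be only part of what the source reports. "The series", "measured", "known", "first", "only" and "open" are said of these compounds alone.

Measured so far in a functional assay on the whole organism with Mus musculus as the target; a lower number here means that less compound is needed, a higher number that more compound is needed for the effect:
- compound 1 `CN(C)C(=O)CCC(=O)c1cccc(C(F)(F)F)c1` gives > 50 mg/kg as a limit
- compound 2 `CCC(C)NC(=O)CCC(=O)c1cccc(C(F)(F)F)c1` gives > 200 mg/kg as a limit
- compound 3 `O=C(CCC(=O)c1cccc(C(F)(F)F)c1)NC1CCCCC1` gives > 200 mg/kg as a limit

Among the measured compounds shown here, no compound yet has a true number in this assay. The results consist only of the limit of > 200 mg/kg in this assay, at which 2 of the 3 values shown sit, and (the limit of > 50 mg/kg in this assay, at which 1 of the 3 values shown sits).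

Compound 3 therefore has no exact position in the series. It is known only by its limit (> 200 mg/kg).

The next change gives compound 4 `CN1CCN(C(=O)CCC(=O)c2cccc(C(F)(F)F)c2)CC1`, with 4-methylpiperazin-1-yl in place of cyclohexylamino on a carbonyl carbon.

All three measured steps also change the group on a carbonyl carbon or on its amide-type nitrogen, so they are the ones that bear on this change. They are a step that the two limits leave unreadable from compound 1 to compound 2 and a step that the two limits leave unreadable from compound 1 to compound 3 and a step that the two limits leave unreadable from compound 2 to compound 3. None of them has a readable size, so none supplies a size or a direction to carry over.

For the measured compounds named here, with no measured step to go on, no step beyond the usual scatter is expected, and the expected step is an at least 1.3-fold lower number from compound 3 to compound 4 (0.12 log units; that floor lies within the scatter). Another limit is a likely outcome. The expected value for compound 4 is 150 mg/kg, with an estimated range from 50 mg/kg to 400 mg/kg.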

Compound 4, dose for half-maximal effect: > 50 mg/kg
Compound 4: only a limit was reported; the forecaster's own chance of this, stated with the estimate: 60%; the middle value lies beyond the limit too.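

In this assay compound 4 gives > 50 mg/kg, which is a limit and not a number. Among the compounds shown here, compound 1, compound 2 and compound 3 are also known only by limits, so no step from any of them to compound 4 can be read. The compounds shown leave open where compound 4 stands relative to the others, and whether any of these amides has a true value in this assay.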